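The source may hold more compounds than are shown below. What is called first, only, known or untested is meant among the compounds shown, and "the series" means these compounds.

Measured so far in an assay on HEK293 cells for inhibition of solute carrier family 22 member 12 (Homo sapiens), read by scintillation counting, with a stated time of 8 min, tested at 100 nM; on this read-out higher numbers stand for a stronger effect at the one concentration tested and lower numbers for a weaker effect:
- compound 1 `CCc1oc2ccccc2c1C(=O)c1cc(Br)c(OCc2cccc(OCC(=O)O)c2)c(Br)c1`: 3%
- compound 2 `CCc1oc2ccccc2c1C(=O)c1cc(Br)c(OCCCC(=O)O)c(Br)c1`: 6%

Compound 2 stands highest of the two numbers in this assay, with compound 1 nearest: a number 3 percentage points higher from compound 1 to compound 2 (within the scatter). Compound 3 `CCc1oc2ccccc2c1C(=O)c1cc(Br)c(OCc2ccc(C(=O)O)cc2)c(Br)c1` is not yet measured; it differs from compound 2 by 4-carboxyphenyl in place of 2-carboxyethyl on a saturated chain carbon bound to an oxygen on an aromatic ring. For the measured compounds named here, the only measured step that bears on this change, a number 3 percentage points higher from compound 1 to compound 2 (within the scatter), put 2-carboxyethyl in place of 3-(carboxymethoxy)phenyl and stayed within the scatter, so returning a carboxyphenyl group is expected to give a step in this assay of no change at the digits printed from compound 2 to compound 3 (within the scatter), none beyond the scatter. Compound 3 is therefore expected to give 6%, in the range -5% to 18%.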

Compound 3, a percentage reported as inhibition, at one concentration (the size of the read-out at that concentration, not a potency): 1%
Beside the measured number, compound 3's estimate is 5 percentage points above it; measured number inside the range.
By their numbers in this assay, from the lowest: compounds 3, 1 and 2 (each within the scatter of the next).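

In this assay putting 4-carboxyphenyl in place of 2-carboxyethyl gives a number 5 percentage points lower from compound 2 to compound 3 (within the scatter) at this position on a saturated chain carbon bound to an oxygen on an aromatic ring. Putting 4-carboxyphenyl in place of 3-(carboxymethoxy)phenyl gives a number 2 percentage points lower from compound 1 to compound 3 (within the scatter) at the same position. The three groups therefore cannot be told apart at the one concentration tested, whether a six-membered aromatic ring is present or not. No evidence is at hand to explain these numbers. Still open, as far as these compounds go, is whether an amine in place of the carboxylic acid, or a longer chain, would give a step beyond the scatter.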